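Moving the Fluoromethyl Along the Side Chain

A few compounds are considered here, and "the series" means these few. Any claim that something is new, unique, unknown or untested is made for them only; others in the source may bear on it.

Compound 1 `COc1cc(C(c2ccc(O)c(OC)c2)[C@H](CF)C(C)C)ccc1O` is tested in a functional assay on HeLa cells (Homo sapiens) for cytotoxicity, read by WST assay, with a stated time of 48 h (on this read-out higher numbers stand for weaker inhibition and lower numbers for stronger inhibition), where compound 1 gives 19000 nM. Among the measured compounds shown here, this is the highest of the two numbers so far: compound 2 `CCCCCCCC[C@H](C(C)C)C(c1ccc(O)c(OC)c1)c1ccc(O)c(OC)c1` gives 3100 nM, and the change is a 6.1-fold lower number from compound 1 to compound 2 (0.79 log units; beyond the scatter). The new compound 3 `COc1cc(C(c2ccc(O)c(OC)c2)[C@H](C)[C@@H](C)CF)ccc1O` is a rearranged version of compound 1: 2-(fluoromethyl)-1-methylpropyl in place of 1-(fluoromethyl)-2-methylpropyl on a saturated chain carbon bound to two aromatic carbons. For the measured compounds named here, the only measured step swaps a small group for a long chain, a different kind of change from the shift of the fluoromethyl group within a side chain of the same size, so it gives little guidance here. With nothing else to go on, the expectation for compound 3 is a number close to that of compound 1, with a step of no change at the digits printed from compound 1 to compound 3 (within the scatter) that stays within the scatter. Compound 3 is therefore estimated at 19000 nM, in a range from 6000 nM to 60000 nM.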

Compound 3, half-maximal inhibitory concentration: 34000 nM
Compound 3: the middle estimate sits 1.8-fold (0.25 log units) below what was measured; low and high end bracket the measured number.
By their numbers in this assay, from the lowest: compound 2; then compounds 1 and 3 (each within the scatter of the next).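

In this assay, putting 2-(fluoromethyl)-1-methylpropyl in place of 1-(fluoromethyl)-2-methylpropyl gives a 1.8-fold higher number from compound 1 to compound 3 (0.25 log units; within the scatter), so at this position the rearrangement does not clearly separate the two compounds. The earlier step showed only what happens when the fluoro is exchanged for a long heptyl chain, whereas this one keeps the same atoms and joins them differently, adding a second defined stereocentre without a change beyond the scatter. No accompanying measurement bears on this result.

On these data alone, it remains open whether a side chain carrying a hydroxyl group or an amine in place of the fluorine would also stay within the scatter of compound 1. The other spatial arrangements of the two stereocentres in compound 3 also remain an open question.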